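This account rests on a few compounds, and the source may have more. Where it says the series, first, only, none or still open, it means among the compounds named here.

Measured so far in a functional assay on the whole organism for antagonist activity, with Mus musculus as the target; on this read-out lower numbers stand for an effect already at smaller amounts and higher numbers for an effect only at larger amounts of compound:
- Compound 1 `CCc1nccn1CC#CCN1CCCC1=O`: 9.7 mg/kg
- Compound 2 `CC(=O)N(C)C(C)C#CCn1ccnc1`: > 100 mg/kg, a limit and not a number
- Compound 3 `CC(=O)N(C)C(C)C#CCn1cncc1C`: 80 mg/kg

Compound 3 gives 80 mg/kg, the higher of the two true numbers, while compound 1 gives 9.7 mg/kg. Compound 2 has only a limit of the assay, as the limit of > 100 mg/kg in this assay, at which 1 of the 3 values shown sits, records.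

Compound 4 `CC(=O)N(C)CC#CCn1cncc1C` differs from compound 3 by one small edit, hydrogen in place of methyl on a saturated chain carbon bound to an amide-type nitrogen and a triple-bonded carbon.

Among the measured compounds shown here, only one measured step offers any guide, an at least 1.2-fold lower number from compound 2 to compound 3 (0.09 log units; that floor lies within the scatter). It concerns methyl in place of hydrogen on an aromatic carbon, so it is a different place, and its floor lies within the scatter. For the measured compounds named here, no measured step tests the chain methyl directly. Compound 1, at 9.7 mg/kg, also has no methyl on that chain carbon, though it differs elsewhere too. A modest move towards a lower number therefore seems likely, and the expected step is a 1.8-fold lower number from compound 3 to compound 4 (0.25 log units; within the scatter). For compound 4 the estimated value is 45 mg/kg, with an expected range from 15 mg/kg to 140 mg/kg.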

Compound 4, dose for half-maximal effect: > 100 mg/kg
Compound 4 was reported as a limit; the forecaster's own chance of this, stated with the estimate: 20%; at least 2.2-fold (0.34 log units) between middle value and limit.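

In this assay compound 4 gives > 100 mg/kg as a limit of the assay and not a number. Hydrogen in place of methyl on this saturated chain carbon gives an at least 1.2-fold higher number from compound 3 to compound 4 (0.09 log units; that floor lies within the scatter) and so offers the first direct look at this position: the change brings no visible gain, although the floor of the step does not establish a real loss either. The true size of the step stays unknown because the read-out ends at a ceiling: the limit of > 100 mg/kg in this assay, at which 2 of the 4 values shown sit.

On these data alone, whether an ethyl group or a longer chain on this carbon would give a lower number than methyl remains open. As far as these compounds go, it is also open whether a true number for compound 4 would lie close to that of compound 3 or far from it.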